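Ethyl Ester in Place of Free Acid: Cytotoxicity Expectation

This account rests on a few compounds, and the source may have more. Where it says the series, first, only, none or still open, it means among the compounds named here.

Compound 1 `COc1ccc(/C=C/C(=O)O)cc1OC(=O)c1nc(C)c(C)nc1C` carries a carboxy group. In a functional assay on EA.hy 926 cells (Homo sapiens) for cytotoxicity, read by MTT assay, with stated times of 24 h and 12 h, tested at 50 uM (a lower number here means a weaker effect, a higher number a stronger effect of the compound at the concentration tested), compound 1 gives 160%. Compound 3 `CCOC(=O)/C=C/c1ccc(OC)c(OC(=O)c2nc(C)c(C)nc2C)c1` is its ethyl ester: ethyl in place of hydrogen on an oxygen next to a carbonyl group. In this assay compound 3 gives 89%, so the change made a number 71 percentage points lower from compound 1 to compound 3 (beyond the scatter).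

Compound 2 `COc1cc(/C=C/C(=O)O)cc(OC)c1OC(=O)c1nc(C)c(C)nc1C` also carries the carboxy group, but its core differs from that of compound 1; the difference between the two cores is not broken down here. In this assay compound 2 gives 96.6%. Its value and that of compound 3 lie within the scatter of each other, while the value of compound 1 stands above both by more than the scatter.

Compound 4 `CCOC(=O)/C=C/c1cc(OC)c(OC(=O)c2nc(C)c(C)nc2C)c(OC)c1` has not yet been measured. It stands to compound 2 exactly as compound 3 stands to compound 1: ethyl in place of hydrogen on an oxygen next to a carbonyl group. The place of the change is the same in both pairs, so this is the same change, seen for the second time among these compounds.

Within the data shown here, the only measured instance of this change is the large drop from compound 1 to compound 3, but compound 2 already starts lower than compound 1, which leaves less room for a drop of equal size, and a single pair is thin evidence. A smaller step is therefore expected, estimated as a number 21.6 percentage points lower from compound 2 to compound 4 (beyond the scatter). Compound 4 is expected to give about 75%, with the estimate spanning from 45% to 105%.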

Compound 4, a percentage reported as activity, at one concentration (the size of the read-out at that concentration, not a potency): -13.6%
Compound 4: the middle estimate sits 88.6 percentage points above what was measured; the measured number lies below the stated range.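

In this assay the change from carboxy to ethoxycarbonyl goes the same way on the second core as on the first, with a number 110.2 percentage points lower from compound 2 to compound 4 (beyond the scatter), so the direction of the step carries over from the core of compound 1 to the core of compound 2. The size of the step does not carry over, as the two steps set side by side show: the same change on two cores in this assay, a number 71 percentage points lower (beyond the scatter) from compound 1 to compound 3 and a number 110.2 percentage points lower (beyond the scatter) from compound 2 to compound 4, 39.2 percentage points apart, beyond the scatter of two such steps A step measured on one of these cores is therefore a fair guide to direction in this small series but a poor guide to size, and two pairs cannot show which feature of the cores goes with the larger step, or whether the same direction would appear on a third core.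

Each pair shown compares a free carboxylic acid only with its ethyl ester, so it remains open how a methyl ester, a longer chain on the same oxygen or an amide in place of the ester would read in this assay. Also open is how any of these compounds would behave at other concentrations, since each number here comes from a single concentration and says nothing about potency.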